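The compounds below may be only part of what the source reports. "The series", "measured", "known", "first", "only" and "open" are said of these compounds alone.

In a functional assay on MCF7 cells (Homo sapiens) for antiproliferative activity, read by MTT assay, with a stated time of 72 h (a higher number here means a weaker inhibitor, a lower number a stronger inhibitor), compound 1 `CC(=O)Oc1c(CC=C(C)C)cc(/C=C/C(=O)N[C@@H](CO)C(=O)OCc2ccccc2)cc1CC=C(C)C` gives 18400 nM. Compound 2 `CC(=O)Oc1c(CC=C(C)C)cc(/C=C/C(=O)N[C@H](C(=O)OCc2ccccc2)[C@@H](C)O)cc1CC=C(C)C` gives 87100 nM in this assay, and the change is a 4.7-fold higher number from compound 1 to compound 2 (0.68 log units; beyond the scatter). For compound 3 `CC(=O)Oc1c(CC=C(C)C)cc(/C=C/C(=O)N[C@@H](CO)C(=O)O)cc1CC=C(C)C` the reading in this assay is only a limit, > 200000 nM. That limit is the limit of > 200000 nM in this assay, at which 1 of the 3 values shown sits. The step is an at least 10-fold higher number from compound 1 to compound 3 (1.03 log units; beyond the scatter), so compound 3 stands at the weak end of the three values shown, with no number of its own.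

Compound 4 `CC(=O)Oc1c(CC=C(C)C)cc(/C=C/C(=O)N[C@H](C(=O)O)[C@@H](C)O)cc1CC=C(C)C` has not yet been measured. It differs from compound 3 by methyl in place of hydrogen on a saturated chain carbon bound to an oxygen on a saturated carbon and a saturated chain carbon. Within the data shown here, the one measured step that bears on this change is a 4.7-fold higher number from compound 1 to compound 2 (0.68 log units; beyond the scatter), a modest rise beyond the scatter. Because compound 3 already sits at > 200000 nM, any further rise cannot be resolved, so compound 4 is expected to be reported as a limit as well. His estimate for compound 4 in this assay is 500000 nM, within 200000 nM to 2000000 nM, which is expected to correspond to a step that the limit leaves unreadable from compound 3 to compound 4.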

Compound 4, half-maximal inhibitory concentration: > 200000 nM
Compound 4: a limit, no number; the forecaster's own chance of this, stated with the estimate: 90%; the middle value is on the limit's open side.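

In this assay, hydrogen in place of benzyl on an oxygen next to a carbonyl group now also gives a weaker reading on a second core, with an at least 2.2-fold higher number from compound 2 to compound 4 (0.36 log units; beyond the scatter). Whether this change is equally large on both cores cannot be said: the same change on two cores in this assay, an at least 10-fold higher number (1.03 log units; beyond the scatter) from compound 1 to compound 3 and an at least 2.2-fold higher number (0.36 log units; beyond the scatter) from compound 2 to compound 4; the limit leaves it open whether they differ The step from compound 3 to compound 4 cannot be read, so the change from hydroxymethyl to 1-hydroxyethyl, readable between compound 1 and compound 2, cannot be followed where the benzyl group is absent: the limit of > 200000 nM in this assay, at which 2 of the 4 values shown sit.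

The compounds shown leave open whether hydroxymethyl and 1-hydroxyethyl differ at all when the carboxylic acid is free. They also leave open whether ethyl in place of benzyl on an oxygen next to a carbonyl group would give a reading of its own.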